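The source may hold more compounds than are shown below. What is called first, only, known or untested is meant among the compounds shown, and "the series" means these compounds.

Measured compounds so far:
- compound 1 `c1cncc(N2CC[C@H]3CN[C@H]3C2)c1`, 48 nM
- compound 2 `Brc1cncc(N2CC[C@H]3CN[C@H]3C2)c1`, 76 nM
- compound 3 `N#Cc1cncc(N2C[C@@H]3CCNC[C@@H]32)c1`, 2560 nM

In a functional assay on HEK293 cells for agonist activity at Neuronal acetylcholine receptor; alpha3/beta4 (Homo sapiens), read by FLIPR (a higher number here means that more compound is needed for the effect, a lower number that less compound is needed), compound 1 gives 48 nM and compound 2 gives 76 nM. The step of a 1.6-fold higher number from compound 1 to compound 2 (0.20 log units; within the scatter) corresponds to the change (bromo in place of hydrogen on an aromatic carbon). In this assay compound 3 gives 2560 nM, the highest number of the three; the difference between the core of compound 3 and the core of compound 1 is not broken down here.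

Compound 4 `N#Cc1cc(N2C[C@@H]3CCNC[C@@H]32)cnc1Br` has not yet been measured. It differs from compound 3 by bromo in place of hydrogen on an aromatic carbon. For the measured compounds named here, this is the same kind of change as the one from compound 1 to compound 2, not the same change: in compound 2 the bromo sits two atoms from the ring nitrogen and meta to a group of 8 heavy atoms, whereas in compound 4 it sits next to the ring nitrogen, ortho to a cyano group and para to a group of 8 heavy atoms. Going by the values given here, the only measured instance of this kind of change, a 1.6-fold higher number from compound 1 to compound 2 (0.20 log units; within the scatter), was small. The expectation for compound 4 rests on that single step and on the value of compound 3, 2560 nM, with the different surroundings of the new bromo adding uncertainty. The step from compound 3 to compound 4 is estimated as a 1.5-fold higher number from compound 3 to compound 4 (0.17 log units; within the scatter). In this assay compound 4 is therefore expected to give about 3800 nM, with a plausible range from 1500 nM to 10000 nM.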

Compound 4, half-maximal effective concentration: 794 nM
For compound 4 the middle estimate is 4.8-fold (0.68 log units) above the measured one; measured number outside the range, below it.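

In this assay, bromo in place of hydrogen on an aromatic carbon gives a 3.2-fold lower number from compound 3 to compound 4 (0.51 log units; beyond the scatter), and this step does not match the earlier one on the core of compound 1: the same change on two cores in this assay, a 1.6-fold higher number (0.20 log units; within the scatter) from compound 1 to compound 2 and a 3.2-fold lower number (0.51 log units; beyond the scatter) from compound 3 to compound 4, 5.1-fold (0.71 log units) apart, beyond the scatter of two such steps A step read on one of these cores is therefore a poor guide to the same kind of change on the other, since it lies within the scatter on the core of compound 1 and beyond it on the core of compound 3. For the compounds shown here, this does not show that the core alone sets the difference: the two pairs also differ in the surroundings of the bromo, which in compound 4 sits next to the ring nitrogen and ortho to a cyano group, and only two steps are available, so neither the core, the place nor the cyano group can be singled out.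

Still open, as far as these compounds go, is how bromo behaves at this same place on the core of compound 1, and how it behaves on the core of compound 3 without the cyano group. Also open, from the compounds shown here alone, is whether chloro, a methoxy group or an amine at the place of the bromo would follow compound 4 in this assay.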